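Methoxy count on the benzylamine ring: compound 4

The source may hold more compounds than are shown below. What is called first, only, known or untested is meant among the compounds shown, and "the series" means these compounds.

For the measured compounds named here, compound 2 `COc1ccc(CNc2nc3cc(N)cc(N)c3nc2-c2ccccc2)cc1OC` stands with the highest number of the three measured so far in a functional assay on A549 cells (Homo sapiens) for inhibition, read by sulforhodamine B assay, with a stated time of 48 h; a higher number here means a weaker inhibitor of growth, a lower number a stronger inhibitor of growth; compound 2 gives 20900 nM. Compound 1 `Nc1cc(N)c2nc(-c3ccccc3)c(Oc3ccc(Cl)c(Cl)c3)nc2c1` gives 18200 nM, within the scatter of compound 2. Compound 3 `COc1cc(CNc2nc3cc(N)cc(N)c3nc2-c2ccccc2)cc(OC)c1OC` gives 4270 nM, clearly apart from the other two.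

Compound 4 `COc1ccc(CNc2nc3cc(N)cc(N)c3nc2-c2ccccc2)cc1` differs from compound 2 by hydrogen in place of methoxy on an aromatic carbon. Going by the values given here, one measured step bears on this place: a 4.9-fold lower number from compound 2 to compound 3 (0.69 log units; beyond the scatter), where a methoxy was added to the same ring and the number fell. Compound 4 runs the opposite way, taking a methoxy off that ring. If the number follows the count of methoxy groups on the ring, the step from compound 2 to compound 4 should raise it; a single step in one direction is a thin basis, however, and a change within the scatter is also plausible. Compound 4 is therefore expected to give about 30000 nM, in a range from 12000 nM to 75000 nM, which is an expected step of a 1.4-fold higher number from compound 2 to compound 4 (0.16 log units; within the scatter).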

Compound 4, concentration for 50% growth inhibition: 21400 nM
The estimate for compound 4 lay 1.4-fold (0.15 log units) above the measured number; low and high end bracket the measured number.
By their numbers in this assay, from the lowest: compound 3; then compounds 1, 2 and 4 (each within the scatter of the next).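

In this assay, going from 3,4-dimethoxyphenyl to 4-methoxyphenyl gives a 1.0-fold higher number from compound 2 to compound 4 (0.01 log units; within the scatter), so taking off this methoxy leaves the number unchanged within the scatter. Set beside a 4.9-fold lower number from compound 2 to compound 3 (0.69 log units; beyond the scatter), where a further methoxy on the same ring lowers the number beyond the scatter, this shows that the number does not simply track the methoxy count, and compound 4 goes against any such trend. No measured data at hand account for the difference between these two steps.

The compounds shown leave open whether a plain benzyl group, with no methoxy on the ring, would keep the number or shift it. They also leave open whether a hydroxy or ethoxy group in place of a methoxy would behave as methoxy does.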